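The source may report more compounds than this note shows. Statements on the series, on what has been measured and on what is new or still open speak of the compounds shown alone.

Among the measured compounds shown here, in a functional assay on KB cells (Homo sapiens) for cytotoxicity, read by MTT assay, with a stated time of 72 h (a lower number here means a stronger inhibitor, a higher number a weaker inhibitor), compound 1 `O=S(=O)(c1ccccc1)c1nc2ccccc2nc1N1CCc2ccccc2C1` gives 26300 nM and compound 2 `Cc1ccc(S(=O)(=O)c2nc3ccccc3nc2N2CCc3ccccc3C2)cc1` gives 32100 nM as the only measured numbers so far. These two numbers lie within the scatter of each other, so compound 2 stands level with compound 1. The change leading to compound 3 `O=S(=O)(c1ccc(Br)cc1)c1nc2ccccc2nc1N1CCc2ccccc2C1` is bromo in place of methyl on an aromatic carbon and amounts to bromo in place of methyl on an aromatic carbon, para to a large group. For the measured compounds named here, the one measured step that bears on it swaps hydrogen for methyl on that same carbon, and it is small: a 1.2-fold higher number from compound 1 to compound 2 (0.09 log units; within the scatter) in this assay and nothing larger has been seen at this place. Bromo itself has not been measured here, so this is thin guidance, and no step beyond the scatter is expected. The estimated step is a 1.3-fold lower number from compound 2 to compound 3 (0.11 log units; within the scatter) in either direction of little meaning. Compound 3 is expected near 25000 nM with an estimated range from 11000 nM to 55000 nM in this measurement.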

Compound 3, half-maximal inhibitory concentration: > 50000 nM
Compound 3: only a limit was reported; the forecaster's own chance of this, stated with the estimate: 10%; middle value at least 2.0-fold (0.30 log units) from the limit.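

Compound 3 gives only a limit, and it is the one compound shown that does so: the limit of > 50000 nM in this assay, at which 1 of the 3 values shown sits. Bromo in this place therefore gives an at least 1.5-fold higher number from compound 2 to compound 3 (0.19 log units; that floor lies within the scatter), and measured against the unsubstituted ring it gives an at least 1.9-fold higher number from compound 1 to compound 3 (0.27 log units; that floor lies within the scatter). Unlike the step from hydrogen to methyl, these steps have no upper end, so in this assay bromo may stand level with hydrogen and methyl or be much weaker than both, but it shows no sign of giving a lower number than either.

On these data alone, whether an amine, a carboxylic acid or a methoxy group on this same carbon would move the number beyond the scatter stays open. So does whether a change to the shared core, rather than to this outer ring, would give a clearly lower number.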